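Dimethylcarbamoyl in place of piperidin-1-yl: cytotoxicity notes

A few compounds are considered here, and "the series" means these few. Any claim that something is new, unique, unknown or untested is made for them only; others in the source may bear on it.

Measured in a toxicity assay on NIH3T3 cells (Mus musculus) for cytotoxicity, read by resazurin assay; on this read-out lower numbers stand for an effect already at smaller amounts and higher numbers for an effect only at larger amounts of compound:
- compound 1 `c1ccc(-c2ccc(Cn3cncc3CNc3ccc(-c4cncs4)c(-c4ccccc4)c3)cc2)cc1`: > 1000 nM (a limit)
- compound 2 `c1ccc(-c2ccc(Cn3cncc3CNc3ccc(N4CCCCC4)c(-c4ccccc4)c3)cc2)cc1`: > 1000 nM (a limit)

Compound 2 has only a limit, and no number, on this read-out: the limit of > 1000 nM in this assay, at which 2 of the 2 values shown sit. Compound 3 `CN(C)C(=O)c1ccc(NCc2cncn2Cc2ccc(-c3ccccc3)cc2)cc1-c1ccccc1` carries dimethylcarbamoyl in place of piperidin-1-yl on an aromatic carbon. Among the compounds with values here, the one measured step bearing on this change, a step that the two limits leave unreadable from compound 1 to compound 2, has no readable size, so it offers no size or direction to carry over into this assay. The expected step is a step that the limit leaves unreadable from compound 2 to compound 3, with no direction firmly expected. Compound 3 is estimated at 3000 nM, with an expected range of 1000 nM to 20000 nM.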

Compound 3, half-maximal effective concentration: > 1000 nM
Compound 3 ended at the assay's limit (the forecaster's own chance of this, stated with the estimate: 75%); the middle value lies beyond the limit too.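

No new step can be read among compound 1, compound 2 and compound 3 in this assay, because all three stop at one limit: the limit of > 1000 nM in this assay, at which 3 of the 3 values shown sit.

The compounds shown leave open whether 1,3-thiazol-5-yl, piperidin-1-yl and dimethylcarbamoyl differ at all in cytotoxicity, and in which direction.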